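This account rests on a few compounds, and the source may have more. Where it says the series, first, only, none or still open, it means among the compounds named here.

Compound 1, `CCN1CCC(Oc2cccnc2)C1` — in an assay on a protein complex for binding affinity to Neuronal acetylcholine receptor; alpha4/beta2 (Rattus norvegicus) (on this read-out higher numbers stand for weaker inhibition and lower numbers for stronger inhibition), compound 1 gives > 10000 nM
Compound 2, `C#Cc1cc(O[C@@H]2CCNC2)cnc1Cl` — in this assay compound 2 gives 46 nM

The value recorded for compound 1 is a limit of the assay, not a number, as the limit of > 10000 nM in this assay, at which 1 of the 2 values shown sits, shows. Going by the values given here, compound 2 is therefore the only compound here with a numerical result in this assay; the other value is a limit, so no ordering between the two can be stated beyond that.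

Compound 3, `Clc1ncc(O[C@@H]2CCNC2)cc1-c1ccccc1`, has not yet been measured in this assay. It differs from compound 2 in one place: phenyl in place of ethynyl on an aromatic carbon. In plain words, a phenyl stands in place of an ethynyl on an aromatic carbon, ortho to the chloro group and two atoms from the ring nitrogen, while the shared core with its pyrrolidine ether is kept.

Among the compounds with values here, no measured pair here shows how this kind of exchange plays out, so the expectation rests on the single number for compound 2 alone. The step from compound 2 to compound 3 is expected to be a loss in binding of modest size, a 3.3-fold higher number from compound 2 to compound 3 (0.51 log units; beyond the scatter), a little beyond the scatter. For compound 3 the estimated value in this assay is 150 nM, with a likely range from 30 nM to 1000 nM.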

Compound 3, half-maximal inhibitory concentration: 75 nM
The estimate for compound 3 lay 2.0-fold (0.30 log units) above the measured number; the measured number falls inside the stated range.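

In this assay, putting a phenyl in place of the ethynyl gives a 1.6-fold higher number from compound 2 to compound 3 (0.21 log units; within the scatter), so this exchange separates the two compounds by no more than repeated measurements of a single compound might. Until now, this position was known only through one number for one small group, whereas it now has two results: the ethynyl, with 2 heavy atoms, and the phenyl, with 6 heavy atoms and a whole aromatic ring, both on the aromatic carbon ortho to the chloro group and two atoms from the ring nitrogen, and the larger group leaves the read-out within the scatter. Going by these compounds alone, nothing measured here explains why the two groups read alike, and the single pair gives no reason for it.

One pair at one position cannot show how far this tolerance reaches, for instance whether a methyl, a carboxylic acid, an amine or a phenyl bearing its own substituent would read the same way at this carbon. It also leaves open whether the phenyl would give a similar number if the chloro group were replaced by a hydrogen atom.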